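A few compounds are considered here, and "the series" means these few. Any claim that something is new, unique, unknown or untested is made for them only; others in the source may bear on it.

Two hydroxamic acids have been measured in an assay on isolated protein for inhibition of protein deacetylase HDAC6 (Homo sapiens), read by fluorescence, with a stated time of 1 h, tested at 100 nM; a lower number here means less inhibition, a higher number more inhibition at the concentration tested (going by the name of the read-out). Compound 1, with the structure `Cc1ccccc1CN1CCC(c2noc(COc3ccc(/C=C/C(=O)NO)cc3)n2)CC1`, gives 68%. Compound 2, with the structure `CN(Cc1nc(C2CCN(Cc3ccccc3F)CC2)no1)c1ncc(C(=O)NO)cn1`, gives 44% in this assay, and compound 2 therefore stands at the lower of the two numbers, with compound 1 a step above it that lies beyond the usual scatter. Among the compounds with values here, no pair among the measured compounds differs in a single place, so no measured step tells how a change at the benzyl group moves the read-out.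

Compound 3, with the structure `CN(Cc1nc(C2CCN(Cc3ccc(F)cc3Cl)CC2)no1)c1ncc(C(=O)NO)cn1`, is the unmeasured compound. It differs from compound 2 as 2-chloro-4-fluorophenyl in place of 2-fluorophenyl on a saturated chain carbon bound to an amine nitrogen in a ring. Without a comparable measured step, the expected change from compound 2 to compound 3 is estimated as a number 4 percentage points higher from compound 2 to compound 3 (within the scatter), which is not beyond the scatter. For compound 3 the inhibition in this assay is estimated at 48%, with a range from 25% to 70%.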

Compound 3, a percentage reported as inhibition, at one concentration (the size of the read-out at that concentration, not a potency): 49%
Compound 3: the middle estimate sits 1 percentage points below what was measured; the range from low to high includes it.
By their numbers in this assay, from the lowest: compounds 2 and 3 (each within the scatter of the next); then compound 1.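

Within the data shown here, the step shows for the first time how a change at this place moves the read-out: 2-chloro-4-fluorophenyl in place of 2-fluorophenyl on a saturated chain carbon bound to an amine nitrogen in a ring gives, in this assay, a number 5 percentage points higher from compound 2 to compound 3 (within the scatter). This place therefore accepts the added chlorine and the second fluorine with no shift that can be told from the scatter, though one step sets no pattern for other groups there. Nothing available here bears on why the step has this size.

As far as these compounds go, it remains open whether a pyridine ring or a methoxyphenyl group at this place would move the inhibition beyond the scatter. From the compounds shown here alone, it is also open whether the same change would give a like step on the core of compound 1.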